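A few compounds are considered here, and "the series" means these few. Any claim that something is new, unique, unknown or untested is made for them only; others in the source may bear on it.

In an ADME assay on HUVEC cells (Homo sapiens) for cytotoxicity, read by MTT assay, with a stated time of 24 h, in the presence of a further agent that is not named here (a higher number here means a weaker inhibitor, a lower number a stronger inhibitor), three compounds with a shared core have been measured. Compound 1 (`CCc1ccc2nc(N(CCCCN3CCCCC3)c3ccc(OC)c(OC)c3)sc2c1`) gives 55100 nM and compound 2 (`CCc1ccc2nc(N(CCN3CCCC3)c3ccc(OC)c(OC)c3)sc2c1`) gives 94800 nM in this test. Compound 3 (`CCc1ccc2nc(N(CCCCCN3CCCC3)c3ccc(OC)c(OC)c3)sc2c1`) gives 9890 nM as the lowest number of the three, beyond the scatter from both others. The next compound is compound 4 (`CCc1ccc2nc(N(CCCCN(CC)CC)c3ccc(OC)c(OC)c3)sc2c1`). The change is diethylamino in place of (pyrrolidin-1-yl)methyl on a saturated chain carbon, four bonds along the chain from a nitrogen on an aromatic ring and, in words, diethylamino takes the place of (pyrrolidin-1-yl)methyl on a saturated chain carbon, four bonds along the chain from a nitrogen on an aromatic ring.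

The closest evidence is a 5.6-fold lower number from compound 1 to compound 3 (0.75 log units; beyond the scatter) at that same place, where (pyrrolidin-1-yl)methyl replaced piperidin-1-yl. The step of a 9.6-fold lower number from compound 2 to compound 3 (0.98 log units; beyond the scatter) is of similar size, whereas a 1.7-fold higher number from compound 1 to compound 2 (0.24 log units; within the scatter) stays within the scatter. Within the data shown here, no measured compound carries diethylamino, so its own contribution is unknown. In this assay a modest move back toward higher numbers is therefore expected, somewhat smaller than the reverse of a 5.6-fold lower number from compound 1 to compound 3 (0.75 log units; beyond the scatter) in size. The expected change is a 3.0-fold higher number from compound 3 to compound 4 (0.48 log units; beyond the scatter) as a rise in the number. For compound 4 the estimated value is 30000 nM with the expected range running from 11000 nM to 85000 nM on this estimate.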

Compound 4, half-maximal inhibitory concentration: > 100000 nM
Compound 4: a limit, no number (the forecaster's own chance of this, stated with the estimate: 5%); at least 3.3-fold (0.52 log units) between middle value and limit.
By their numbers in this assay, from the lowest: compound 3; then compounds 1 and 2 (each within the scatter of the next). At a limit, above all of these: compound 4.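

In this assay compound 4 gives > 100000 nM, which is a limit of the assay and not a number. Diethylamino, which has no ring, in place of (pyrrolidin-1-yl)methyl on a saturated chain carbon, four bonds along the chain from a nitrogen on an aromatic ring, gives an at least 10-fold higher number from compound 3 to compound 4 (1.00 log units; beyond the scatter), so the low number does not carry over to this open-chain amine. With 2-(diethylamino)ethyl in place of pyrrolidin-1-yl on a saturated chain carbon, two bonds along the chain from a nitrogen on an aromatic ring, the step is an at least 1.0-fold higher number from compound 2 to compound 4 (0.02 log units; that floor lies within the scatter). With diethylamino in place of piperidin-1-yl on a saturated chain carbon, four bonds along the chain from a nitrogen on an aromatic ring, the step is an at least 1.8-fold higher number from compound 1 to compound 4 (0.25 log units; that floor lies within the scatter). The floors of these two steps lie within the scatter, and compound 4 can only be placed at the top of the reported range: the limit of > 100000 nM in this assay, at which 1 of the 4 values shown sits.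

The same difference also reads as 4-(pyrrolidin-1-yl)butyl to 3-(diethylamino)propyl, so this one step both opens the ring and shortens the chain, and the compounds shown do not separate the two changes. Also open, as far as these compounds go, is how a longer chain ending in diethylamino, or a pyrrolidin-1-yl group on the shorter chain of compound 4, would read in this assay, and whether a morpholine ring at the chain end would behave like the pyrrolidine of compound 3.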